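The compounds below may be only part of what the source reports. "The series", "measured", "known", "first", "only" and "open" are said of these compounds alone.

Three compounds sharing one core were tested in a functional assay on DU-145 cells (Homo sapiens) for cytotoxicity, read by CCK-8 assay; a higher number here means a weaker inhibitor, a lower number a stronger inhibitor. Compound 1, `Oc1cccc(-c2cc(-c3ccoc3)cc(-c3ccccc3O)n2)c1`, gives 2790 nM in this assay. Compound 2, `Oc1ccc(-c2cc(-c3ccoc3)cc(-c3ccccc3O)n2)cc1`, gives 28000 nM, and compound 3, `Oc1cccc(-c2cc(-c3ccccn3)cc(-c3ccccc3O)n2)c1`, gives 17100 nM. The step of a 10-fold higher number from compound 1 to compound 2 (1.00 log units; beyond the scatter) arises from the change (4-hydroxyphenyl in place of 3-hydroxyphenyl on an aromatic carbon). The step of a 6.1-fold higher number from compound 1 to compound 3 (0.79 log units; beyond the scatter) comes from the change (pyridin-2-yl in place of furan-3-yl on an aromatic carbon), which is also how the core of compound 3 differs from the core of compound 1. Compound 4, `Oc1ccc(-c2cc(-c3ccccn3)cc(-c3ccccc3O)n2)cc1`, has not yet been measured. It differs from compound 3 by 4-hydroxyphenyl in place of 3-hydroxyphenyl on an aromatic carbon, the same kind of change as that between compound 1 and compound 2, though here the place is meta to a pyridin-2-yl group rather than meta to a furan-3-yl group. Compound 3 already gives 17100 nM, so the same change is expected to carry less far than it did before. The expected step is therefore a 4.7-fold higher number from compound 3 to compound 4 (0.67 log units; beyond the scatter), set beside the earlier step of a 10-fold higher number from compound 1 to compound 2 (1.00 log units; beyond the scatter). Compound 4 is thus estimated at 80000 nM in this assay.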

Compound 4, half-maximal inhibitory concentration: 25400 nM
Compound 4: middle estimate off by 3.1-fold (0.50 log units), on the high side; low and high end bracket the measured number.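

In this assay, 4-hydroxyphenyl in place of 3-hydroxyphenyl on the core bearing pyridin-2-yl gives a 1.5-fold higher number from compound 3 to compound 4 (0.17 log units; within the scatter), and pyridin-2-yl in place of furan-3-yl on the core bearing 4-hydroxyphenyl gives a 1.1-fold lower number from compound 2 to compound 4 (0.04 log units; within the scatter). The size of the hydroxyphenyl change therefore does not carry from the core of compound 1 to the core of compound 3: the same change on two cores in this assay, a 10-fold higher number (1.00 log units; beyond the scatter) from compound 1 to compound 2 and a 1.5-fold higher number (0.17 log units; within the scatter) from compound 3 to compound 4, 6.8-fold (0.83 log units) apart, beyond the scatter of two such steps The pyridin-2-yl change likewise depends on which hydroxyphenyl group is present, but these four compounds form a single square, so the two gaps are one observation seen from two sides, showing that the two changes do not add up without showing why or whether this holds beyond these compounds: the same change on two cores in this assay, a 6.1-fold higher number (0.79 log units; beyond the scatter) from compound 1 to compound 3 and a 1.1-fold lower number (0.04 log units; within the scatter) from compound 2 to compound 4, 6.8-fold (0.83 log units) apart, beyond the scatter of two such steps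

The compounds shown leave open whether a thiophen-3-yl or plain phenyl group in place of furan-3-yl would keep the same dependence on the hydroxyphenyl group. They also leave open how an amine in place of the hydroxyl would behave on either core.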